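Trifluoromethyl on the distal phenyl of compound 2

A few compounds are considered here, and "the series" means these few. Any claim that something is new, unique, unknown or untested is made for them only; others in the source may bear on it.

Of the compounds shown here, two with the shared thiazole-ether acid scaffold have been measured. Compound 1 `Cc1nc(-c2ccccc2)sc1COc1ccc(OCC(=O)O)c(F)c1` in an assay on CHO cells for agonist activity at Free fatty acid receptor 1 (Homo sapiens), read by FLIPR (a higher number here means that more compound is needed for the effect, a lower number that less compound is needed), gives 374 nM. Compound 2 `Cc1nc(-c2ccccc2)sc1COc1ccc2c(c1)OCC2CC(=O)O` in this assay gives 102 nM, the lowest of the two numbers, and the gap between compound 1 and compound 2 lies beyond the usual scatter. Compound 3 `Cc1nc(-c2ccc(C(F)(F)F)cc2)sc1COc1ccc2c(c1)OCC2CC(=O)O` remains to be measured in this assay. It differs from compound 2 by a single change: trifluoromethyl in place of hydrogen on an aromatic carbon, which at one bond further out reads as phenyl to 4-(trifluoromethyl)phenyl. Going by the values given here, no measured pair in this set shows what such a change does, so the expectation rests on compound 2 alone, whose 102 nM serves as the anchor. The step from compound 2 to compound 3 is estimated to be small, likely within the scatter or a modest improvement, a 1.5-fold lower number from compound 2 to compound 3 (0.16 log units; within the scatter). For compound 3 the expected value is 70 nM, with a range from 25 nM to 250 nM.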

Compound 3, half-maximal effective concentration: 113 nM
Compound 3: middle estimate off by 1.6-fold (0.21 log units), on the low side, and the stated range covers the measured number.
By their numbers in this assay, from the lowest: compounds 2 and 3 (each within the scatter of the next); then compound 1.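

Phenyl to 4-(trifluoromethyl)phenyl is the first single change in this set that can be read, and in this assay it gives a 1.1-fold higher number from compound 2 to compound 3 (0.04 log units; within the scatter). This shows that a trifluoromethyl, with its 4 heavy atoms, can stand on this aromatic carbon, para to a large group, with compound 3 remaining within the scatter of compound 2. No measurement at hand bears on why the two compounds match.

The compounds shown leave open whether other groups on the same carbon, such as a chlorine, a methoxy, a nitrile or an amine, would also match compound 2. They also leave open what a trifluoromethyl does on another carbon of that ring, or on the same carbon of compound 1.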